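A Single Group Swap on Compound 3

The compounds below may be only part of what the source reports. "The series", "measured", "known", "first", "only" and "open" are said of these compounds alone.

In an ADME assay on the whole organism (Mus musculus, strain CD-1) for pharmacokinetics, at a dose of 10 mg/kg by the oral route (on this read-out higher numbers stand for higher oral bioavailability and lower numbers for lower oral bioavailability), compound 3 (`COc1cc([C@](O)(CCN(C)C)[C@@H](c2cc3cc(C#N)ccc3nc2OC)c2cccc(C)c2F)cc(OC(F)F)n1`) gives 66%. That lies within the scatter of compound 1 (`CCOc1cc([C@](O)(CCN(C)C)[C@@H](c2cc3cc(Br)ccc3nc2OC)c2ccnc(OC)c2OC)cc(OC)n1`) at 70%, whereas compound 2 (`COc1cc([C@](O)(CCN(C)C)[C@@H](c2cc3cc(Br)ccc3nc2OC)c2ccnc(OC)c2OC)cc(OC(C)C)n1`) gives 22%, a gap beyond the scatter. Compound 4 (`COc1cc([C@](O)(CCN(C)C)[C@@H](c2cc3cc(C#N)ccc3nc2OC)c2ccnc(OC)c2OC)cc(OC(F)F)n1`) differs from compound 3 in one place: 2,3-dimethoxypyridin-4-yl in place of 2-fluoro-3-methylphenyl on a saturated chain carbon bound to an aromatic carbon and a saturated chain carbon. Going by the values given here, no measured step covers this swap. The only one, a number 48 percentage points lower from compound 1 to compound 2 (beyond the scatter), is a large step at a different place, so it bears on the swap only indirectly. Compound 1 carries the incoming 2,3-dimethoxypyridin-4-yl and gives 70%, although compound 2 carries it too and gives 22%. In this assay, no step beyond the scatter is therefore expected: the estimate is a number 6 percentage points lower from compound 3 to compound 4 (within the scatter). For compound 4 the expected value is 60%, within an estimated range of 35% to 80%.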

Compound 4, oral bioavailability: 43%
Estimate against measurement, compound 4: 17 percentage points above; measured number inside the range.
By their numbers in this assay, from the lowest: compound 2; then compound 4; then compounds 3 and 1 (each within the scatter of the next).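

In this assay, the group on this saturated chain carbon clearly matters: 2,3-dimethoxypyridin-4-yl in place of 2-fluoro-3-methylphenyl gives a number 23 percentage points lower from compound 3 to compound 4 (beyond the scatter) with the rest of the molecule unchanged. Going by these compounds alone, this is the first measured step at this place, and it shows that this swap alone can shift oral bioavailability. No available measurement explains the drop. Still open, from the compounds shown here alone, is which part of the change counts: the ring nitrogen, the two methoxy groups, or the lost fluorine and methyl. Going by these compounds, how an unsubstituted phenyl would fare at this place also remains unknown.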